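The source may report more compounds than this note shows. Statements on the series, on what has been measured and on what is new or still open speak of the compounds shown alone.

Measured so far:
compound 1, `CCN(C(=O)c1ccccc1OCc1ccccc1)[C@@H]1CCC[C@H](NC(C)=O)C1`: in an assay on HEK293 cells for inhibition of transient receptor potential cation channel subfamily M member 8 (Homo sapiens), read by FLIPR and calcium flux (a lower number here means a stronger inhibitor, a higher number a weaker inhibitor), compound 1 gives > 5000 nM; this is a limit of the assay, not a number.
compound 2, `N[C@H]1CCC[C@@H](N(C(=O)c2ccccc2OCc2ccccc2)C2CCC2)C1`: in this assay compound 2 gives 794 nM.

Compound 2 stands alone with the only number shown in this assay. Within the data shown here, the other value recorded is a limit, so no measured step separates compound 2 from compound 1; the limit is recorded as the limit of > 5000 nM in this assay, at which 1 of the 2 values shown sits, and nothing more can be read from it. Compound 1 also differs from compound 2 in more than one place, so it does not isolate any single change.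

Compound 3, `CCCCN(C(=O)c1ccccc1OCc1ccccc1)[C@@H]1CCC[C@H](N)C1`, has not yet been measured. It differs from compound 2 in one place: butyl in place of cyclobutyl on an amide-type nitrogen. The chain entering is open where the ring leaving is closed, and both are carbon only. Among the measured compounds shown here, no step between measured compounds covers this kind of change, so the series itself gives no size for it. The expectation is for a small step from compound 2 to compound 3 of a 1.4-fold higher number from compound 2 to compound 3 (0.14 log units; within the scatter), within the scatter or at most slightly toward weaker. Compound 3 is accordingly expected to give 1100 nM in this assay, with a range from 400 nM to 3200 nM.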

Compound 3, antagonist equilibrium constant: 1560 nM
For compound 3 the middle estimate is 1.4-fold (0.15 log units) below the measured one; low and high end bracket the measured number.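

In this assay, the amide-type nitrogen now has its first readable step: butyl in place of cyclobutyl gives a 2.0-fold higher number from compound 2 to compound 3 (0.29 log units; within the scatter). For this pair of carbon-only groups, an open chain and a closed ring are not told apart by the assay, so the compounds shown give no sign that the ring is needed on this nitrogen. Nothing shown bears on a cause for this step, and a step within the scatter asks for none.

Open, as far as these compounds go, is how this nitrogen would read with a group of another size or kind, such as methyl, cyclohexyl, a longer chain like octyl, or a chain ending in an amine or a carboxylic acid. From the compounds shown here alone, compound 1 gives > 5000 nM, which is a limit of the assay and not a number, and because compound 1 differs from compound 2 and compound 3 in more than one place, the part played by the acetylated nitrogen on the saturated ring also stays open.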